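A Methyl on the Ring Oxygen: Compound 4 Foreseen

This account rests on a few compounds, and the source may have more. Where it says the series, first, only, none or still open, it means among the compounds named here.

Of the compounds shown here, three have been tested in a functional assay (QGY7701 cells, Homo sapiens) for inhibition, read by MTT assay, with a stated time of 48 h; on this read-out higher numbers stand for weaker inhibition and lower numbers for stronger inhibition. Compound 1 `COc1ccc(NC(=O)/C=C/c2coc3cc(OC)ccc3c2=O)cc1` carries a 4-methoxyphenyl on the amide-type nitrogen; in this assay compound 1 gives only a limit, > 100000 nM. Compound 2 `COc1ccc(NC(=O)/C=C/c2coc3cc(O)ccc3c2=O)cc1` differs from compound 1 in one place, and in this assay compound 2 likewise gives only a limit, > 100000 nM. Both values sit at the limit of > 100000 nM in this assay, at which 2 of the 3 values shown sit, which leaves a step that the two limits leave unreadable from compound 2 to compound 1 without a readable size. Among the compounds with values here, compound 3 `Cc1ccccc1NC(=O)/C=C/c1coc2cc(O)ccc2c1=O` differs from compound 2 by 2-methylphenyl in place of 4-methoxyphenyl on an amide-type nitrogen and is the only compound with a number: in this assay compound 3 gives 9320 nM. That change produced an at least 10-fold lower number from compound 2 to compound 3 (1.03 log units; beyond the scatter).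

Compound 4 `COc1ccc2c(=O)c(/C=C/C(=O)Nc3ccccc3C)coc2c1` has not yet been measured. It differs from compound 3 by methyl in place of hydrogen on an oxygen on an aromatic ring, the same change made from compound 2 to compound 1 (methyl in place of hydrogen on an oxygen on an aromatic ring), on the same place. The measured pair leaves the size of that change unknown, so the data give no direction for it. Compound 4 is therefore expected to land close to compound 3, with an expected step of a 1.6-fold higher number from compound 3 to compound 4 (0.21 log units; within the scatter), the width of the range reflecting the unreadable earlier step. Compound 4 is estimated at 15000 nM, between 4000 nM and 60000 nM.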

Compound 4, half-maximal inhibitory concentration: 22500 nM
The estimate for compound 4 lay 1.5-fold (0.18 log units) below the measured number; the measured number falls inside the stated range.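

Carried onto the core of compound 3, the change from hydroxy to methoxy gives a 2.4-fold higher number from compound 3 to compound 4 (0.38 log units; beyond the scatter) in this assay, so on this core the methyl on the ring oxygen has a readable, modest size. The same change on the core of compound 2 cannot be read, as both of its ends are limits of the assay, and so these compounds show nothing about whether the step keeps its size or even its direction from one core to the other. The other change, 2-methylphenyl in place of 4-methoxyphenyl on the amide-type nitrogen, now gives an at least 4.4-fold lower number from compound 1 to compound 4 (0.64 log units; beyond the scatter) with methoxy on the ring, and it lowers the number on both cores: the same change on two cores in this assay, an at least 10-fold lower number (1.03 log units; beyond the scatter) from compound 2 to compound 3 and an at least 4.4-fold lower number (0.64 log units; beyond the scatter) from compound 1 to compound 4; the limit leaves it open whether they differ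

The compounds shown leave open whether the hydroxy to methoxy step would hold with any other group on the amide-type nitrogen, as 2-methylphenyl is the only such group here that gives numbers. They also leave open how a longer chain such as ethyl on the ring oxygen, or an amine or a carboxylic acid on the phenyl of the amide, would read in this assay.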